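The source may hold more compounds than are shown below. What is called first, only, known or untested is meant among the compounds shown, and "the series" means these compounds.

Compound 1 `O=C(Nc1ccccc1)OC1CCN(Cc2ccccc2)CC1` is the starting point here. In an assay on BTI-TN-5B1-4 cells for inhibition of Amine oxidase [flavin-containing] A (Homo sapiens), read by fluorescence and Amplex Red, using microsomes, with a stated time of 15 min (on this read-out higher numbers stand for weaker inhibition and lower numbers for stronger inhibition), compound 1 reaches only the limit of > 100000 nM, which is a boundary of the test rather than a measured number. Compound 2 `C#CCN1CCCC(OC(=O)Nc2ccc(C(C)C)cc2)C1` shares the carbamate core of compound 1 but differs at both ends. Compound 2 likewise stops at the limit of > 100000 nM in this assay. Both results rest at the limit of > 100000 nM in this assay, at which 2 of the 2 values shown sit, so compound 1 stands at the edge of what this test can report, together with compound 2. Compound 3 `CC(C)c1ccc(NC(=O)OC2CCN(Cc3ccccc3)CC2)cc1` keeps the rest of compound 1 and introduces (isopropyl in place of hydrogen on an aromatic carbon). For the measured compounds named here, no measured pair isolates this change. Because compound 2 already carries the isopropyl group and gives > 100000 nM, the change is expected to bring no gain beyond the scatter. Compound 3 is expected to give 150000 nM, within a range from 30000 nM to 500000 nM. The estimated step is a step that the limit leaves unreadable from compound 1 to compound 3, essentially none.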

Compound 3, half-maximal inhibitory concentration: > 100000 nM
Compound 3 gave a limit, no number; the forecaster's own chance of this, stated with the estimate: 80%; the middle value lies beyond the limit too.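

For the compounds shown here, compound 1 and compound 3 both give only a limit, not a number, so no step between them can be read: the limit of > 100000 nM in this assay, at which 3 of the 3 values shown sit. The compounds shown leave open how strongly, if at all, each one inhibits in this assay, and whether isopropyl in place of hydrogen makes any difference.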